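This account rests on a few compounds, and the source may have more. Where it says the series, first, only, none or still open, it means among the compounds named here.

Measured in a functional assay on SW-620 cells (Homo sapiens) for inhibition, read by MTT assay, with a stated time of 48 h; a higher number here means a weaker inhibitor, a lower number a stronger inhibitor:
compound 1 `Cc1ccc(NC(=S)NC(=O)c2ccc(OCc3ccc(Cl)cc3Cl)cc2)cc1-c1nc2ccccc2[nH]1` gives 57200 nM
compound 2 `Cc1ccc(NC(=S)NC(=O)c2ccc(OCc3ccc(F)cc3)cc2)cc1-c1nc2ccccc2[nH]1` gives 40500 nM
compound 3 `Cc1ccc(NC(=O)NC(=O)c2ccc(OCc3ccc(Cl)cc3Cl)cc2)cc1-c1nc2ccccc2[nH]1` gives 12200 nM

Compound 1 and compound 2 share one core and differ only by 4-fluorophenyl in place of 2,4-dichlorophenyl on a saturated chain carbon bound to an oxygen on an aromatic ring. That exchange gave a 1.4-fold lower number from compound 1 to compound 2 (0.15 log units; within the scatter), so the two values stand together. Compound 3 carries a different core; how its core differs from that of compound 1 is not broken down here. Compound 3 has the lowest number of the three in this assay, and its steps from compound 2 and from compound 1 are both beyond the scatter.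

Compound 4 `Cc1ccc(NC(=O)NC(=O)c2ccc(OCc3ccc(F)cc3)cc2)cc1-c1nc2ccccc2[nH]1` is not yet measured. It differs from compound 3 by 4-fluorophenyl in place of 2,4-dichlorophenyl on a saturated chain carbon bound to an oxygen on an aromatic ring, the same change as that from compound 1 to compound 2, at the same place. The step in this assay is expected to be a 1.4-fold lower number from compound 3 to compound 4 (0.13 log units; within the scatter), resting on the earlier step of a 1.4-fold lower number from compound 1 to compound 2 (0.15 log units; within the scatter). Compound 4 is therefore estimated at 9000 nM, between 4000 nM and 22000 nM.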

Compound 4, half-maximal inhibitory concentration: 35100 nM
Compound 4: middle estimate off by 3.9-fold (0.59 log units), on the low side, and the stated range ends below it.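

In this assay, 4-fluorophenyl in place of 2,4-dichlorophenyl gave a 2.9-fold higher number from compound 3 to compound 4 (0.46 log units; beyond the scatter) on the core of compound 3. The exchange did not carry over with the same result from one core to the other: the same change on two cores in this assay, a 1.4-fold lower number (0.15 log units; within the scatter) from compound 1 to compound 2 and a 2.9-fold higher number (0.46 log units; beyond the scatter) from compound 3 to compound 4, 4.1-fold (0.61 log units) apart, beyond the scatter of two such steps. Its outcome therefore differs between these two pairs, but with a single pair on each core, this does not show how the core shapes the outcome or which step would hold on a further core.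

Still open, on these data alone, is whether the difference between the two cores would persist with an amine or a longer chain in place of the halogenated phenyl. Also open, as far as these compounds go, is whether it extends beyond this one assay.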